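Aryl Sulfonamide Swap on a Nicotinamide Chemokine Receptor Ligand

This account rests on a few compounds, and the source may have more. Where it says the series, first, only, none or still open, it means among the compounds named here.

Measured compounds:
compound 1 `O=C(NCc1ccc(CNS(=O)(=O)c2ccc([N+](=O)[O-])cc2)cc1)c1cccnc1` gives 100 nM
compound 2 `O=C(NCc1ccc(CNS(=O)(=O)c2ccc(Cl)cc2)cc1)c1cccnc1` gives 1000 nM
compound 3 `O=C(NCc1ccc(CNS(=O)(=O)c2cccc3ccccc23)cc1)c1cccnc1` gives 1000 nM

In an assay on MDA-MB-231 cells for displacement of a labelled ligand from C-X-C chemokine receptor type 4 (Homo sapiens), read by fluorescence and microscopy, with stated times of 10 min and 30 min (a lower number here means that less compound is needed, a higher number that more compound is needed for the effect), compound 3 stands level with compound 2, and together these two give the highest numbers of the three; the step of a 10-fold higher number from compound 1 to compound 3 (1.00 log units; beyond the scatter) sets compound 1 apart as the lowest. The step of no change at the digits printed from compound 2 to compound 3 (within the scatter) shows that replacing 4-chlorophenyl with naphthalen-1-yl made no difference beyond the scatter, while a 10-fold higher number from compound 1 to compound 2 (1.00 log units; beyond the scatter) shows what exchanging the nitro group costs.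

Compound 4 `Cc1ccccc1S(=O)(=O)NCc1ccc(CNC(=O)c2cccnc2)cc1` differs from compound 3 as follows: 2-methylphenyl in place of naphthalen-1-yl on a sulfonyl sulfur. Within the data shown here, the bearing steps are no change at the digits printed from compound 2 to compound 3 (within the scatter), within the scatter, and a 10-fold higher number from compound 1 to compound 3 (1.00 log units; beyond the scatter), which is the only step beyond it. Compound 4, like compound 3 and compound 2, carries no nitro group, and does not reverse that step. Compound 4 is therefore expected to stay near compound 3, with a step of no change at the digits printed from compound 3 to compound 4 (within the scatter) no larger than the scatter. The estimate for compound 4 is 1000 nM, within the range 300 nM to 3000 nM.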

Compound 4, effective concentration (reported as EC, without a stated level of effect): 1000 nM
Beside the measured number, compound 4's estimate shows no gap at the digits printed; the measured number falls inside the stated range.
By their numbers in this assay, from the lowest: compound 1; then compounds 2, 3 and 4 (each within the scatter of the next).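

With no change at the digits printed from compound 3 to compound 4 (within the scatter) the exchange of naphthalen-1-yl for 2-methylphenyl, which leaves one six-membered aromatic ring of carbon only in place of two, does not move the number in this assay beyond the scatter. Together with no change at the digits printed from compound 2 to compound 4 (within the scatter) this gives three different aryl groups on the sulfonyl sulfur that cannot be told apart here, while a 10-fold higher number from compound 1 to compound 4 (1.00 log units; beyond the scatter) leaves the 4-nitrophenyl of compound 1 as the only group shown that stands apart.

The compounds shown leave open whether the nitro group itself sets compound 1 apart, or whether another group on that aromatic carbon, such as a nitrile, a carboxylic acid or an amine, would do the same. They also leave open how any change outside the aryl group on the sulfonyl sulfur would read. No measurement offered here bears on why these numbers fall as they do.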